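A few compounds are considered here, and "the series" means these few. Any claim that something is new, unique, unknown or untested is made for them only; others in the source may bear on it.

Measured so far in an in vitro functional assay on cells for agonist activity at Bombesin receptor subtype-3 (Homo sapiens), read by luminescence and calcium flux; on this read-out lower numbers stand for an effect already at smaller amounts and higher numbers for an effect only at larger amounts of compound:

- compound 1 `O=C(O)c1ccccc1-c1ccc(CCc2ncc(Cc3cccc(F)c3)[nH]2)cc1` gives 159 nM
- compound 2 `CC(C)CCc1cnc(CCc2ccc(-c3ccccc3C(=O)O)cc2)[nH]1` gives 119 nM
- compound 3 `O=C(O)c1ccccc1-c1ccc(CCc2ncc(CC3CC3)[nH]2)cc1` gives 1000 nM

Compound 3 stands at the highest number of these three; its steps to the other two, a 6.3-fold higher number from compound 1 to compound 3 (0.80 log units; beyond the scatter) and an 8.4-fold higher number from compound 2 to compound 3 (0.92 log units; beyond the scatter), both lie beyond the scatter, so it is the least potent of the measured set. Compounds 1 and 2 sit within the scatter of each other, as a 1.3-fold lower number from compound 1 to compound 2 (0.13 log units; within the scatter) shows.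

Compound 4 `CCC(C)(CC)Cc1cnc(CCc2ccc(-c3ccccc3C(=O)O)cc2)[nH]1` has not yet been measured. It differs from compound 3 in one place: 1-ethyl-1-methylpropyl in place of cyclopropyl on a saturated chain carbon bound to an aromatic carbon. Among the measured compounds shown here, the steps that bear on this change are the two that lead away from cyclopropyl at the same place. Both exchanges of the small ring for a larger group, whether isobutyl or 3-fluorophenyl, came with a clearly lower number. The entering group is a branched chain of six carbons, closest in kind to the isobutyl of compound 2.

Compound 4 is therefore expected to show a lower number than compound 3, with an estimated step of a 5.0-fold lower number from compound 3 to compound 4 (0.70 log units; beyond the scatter). The estimate for compound 4 in this assay is 200 nM, with a range from 60 nM to 700 nM.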

Compound 4, half-maximal effective concentration: 76 nM
The estimate for compound 4 lay 2.6-fold (0.42 log units) above the measured number, within the range that was stated.
By their numbers in this assay, from the lowest: compounds 4, 2 and 1 (each within the scatter of the next, the first and the last beyond it); then compound 3.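

In this assay, the open-chain 1-ethyl-1-methylpropyl group gives the largest step yet seen on this saturated chain carbon (a 13-fold lower number from compound 3 to compound 4 (1.12 log units; beyond the scatter)), so leaving cyclopropyl can pay off more than the earlier exchanges showed. Further branching brings no penalty here: the new group stays level with isobutyl (a 1.6-fold lower number from compound 2 to compound 4 (0.19 log units; within the scatter)) and edges just past 3-fluorophenyl (a 2.1-fold lower number from compound 1 to compound 4 (0.32 log units; beyond the scatter)), which suggests that quite different groups can serve equally well at this place. Nothing available explains why the cyclopropyl compound trails the other three.

On these data alone, it remains open whether the branching itself matters, which a straight hexyl chain at this place would help to test. As far as these compounds go, how a group carrying an amine or a hydroxyl would behave here also remains unknown.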